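The source may hold more compounds than are shown below. What is called first, only, known or untested is meant among the compounds shown, and "the series" means these compounds.

Of the compounds shown here, three share one core and have been tested in a functional assay on A549 cells (Homo sapiens) for antiproliferative activity, read by MTT assay, with a stated time of 48 h; a higher number here means a weaker inhibitor, a lower number a stronger inhibitor. Compound 1 `CC1(C)CC(NC(=O)c2ccc(Nc3ncc([N+](=O)[O-])c(NC4CCCC4)n3)cc2)CC(C)(C)N1[O]` gives 33200 nM. Compound 2 `CCN1CCN(c2nc(Nc3ccc(C(=O)NC4CC(C)(C)N([O])C(C)(C)C4)cc3)ncc2[N+](=O)[O-])CC1` gives 1960 nM. Compound 3 `CC1(C)CC(NC(=O)c2ccc(Nc3ncc([N+](=O)[O-])c(N4CCN(c5ccc(F)cc5)CC4)n3)cc2)CC(C)(C)N1[O]` gives 10300 nM. Compound 2 thus holds the lowest number of the three, with compound 3 nearest and compound 1 furthest away.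

Compound 4 `Cc1cc(Nc2nc(Nc3ccc(C(=O)NC4CC(C)(C)N([O])C(C)(C)C4)cc3)ncc2[N+](=O)[O-])n[nH]1` differs from compound 2 in one place: (5-methyl-1H-pyrazol-3-yl)amino in place of 4-ethylpiperazin-1-yl on an aromatic carbon. Within the data shown here, two measured steps bear on this change. The first, a 17-fold lower number from compound 1 to compound 2 (1.23 log units; beyond the scatter), shows that exchanging the group on this aromatic carbon can move the number a long way. The second, a 5.3-fold higher number from compound 2 to compound 3 (0.72 log units; beyond the scatter), shows that altering the group on that carbon in another way raises the number by a smaller amount. Both steps tell the same thing: this position is sensitive, and compound 2 carries the group that has so far done best there. Replacing it with the incoming amino-linked aromatic group is expected to give a higher number in this assay, a 2.3-fold higher number from compound 2 to compound 4 (0.36 log units; beyond the scatter), although the spread of the two measured steps leaves much room. Compound 4 is therefore estimated at 4500 nM, within a range from 1000 nM to 18000 nM.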

Compound 4, half-maximal inhibitory concentration: 15300 nM
The estimate for compound 4 lay 3.4-fold (0.53 log units) below the measured number; measured number inside the range.
By their numbers in this assay, from the lowest: compound 2; then compounds 3 and 4 (each within the scatter of the next); then compound 1.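

In this assay, (5-methyl-1H-pyrazol-3-yl)amino in place of 4-ethylpiperazin-1-yl gives a 7.8-fold higher number from compound 2 to compound 4 (0.89 log units; beyond the scatter) and so costs much of the advantage held by compound 2, although the entering group carries hydrogen-bond donors and the leaving group has none. Against the other amino-linked compound, 5-methyl-1H-pyrazol-3-yl in place of cyclopentyl gives a 2.2-fold lower number from compound 1 to compound 4 (0.34 log units; beyond the scatter), a smaller gain, so among these four compounds both amino-linked groups stand above compound 2 in number, while compound 3 shows that keeping the piperazine ring does not by itself hold the low number. Nothing shown here accounts for these shifts at the position next to the ring nitrogen and ortho to the nitro group.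

The compounds shown leave open whether the low number of compound 2 depends on the ethyl group or on the ring that carries it, which a methyl or a hydrogen on that ring nitrogen, or a morpholin-4-yl group at the same carbon, could separate. They also leave open what the methyl on the pyrazole contributes, and whether an unsubstituted pyrazol-3-ylamino group would sit closer to compound 2 or to compound 4.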